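Swapping Nitro for Chloro on the Anilide Ring

The source may hold more compounds than are shown below. What is called first, only, known or untested is meant among the compounds shown, and "the series" means these compounds.

Of the compounds shown here, three sharing one core have been measured in a functional assay on L1210 cells (Mus musculus) for cytotoxicity; on this read-out lower numbers stand for stronger inhibition and higher numbers for weaker inhibition. Compound 1 `O=C(/C=C/C(=O)N1C/C(=C\c2ccc([N+](=O)[O-])cc2)C(=O)/C(=C/c2ccc([N+](=O)[O-])cc2)C1)Nc1ccc(Cl)c(Cl)c1` gives 1700 nM. Compound 2 `CC(=O)c1ccc(NC(=O)/C=C/C(=O)N2C/C(=C\c3ccc([N+](=O)[O-])cc3)C(=O)/C(=C/c3ccc([N+](=O)[O-])cc3)C2)cc1` gives 1400 nM. Compound 3 `O=C(/C=C/C(=O)N1C/C(=C\c2ccc([N+](=O)[O-])cc2)C(=O)/C(=C/c2ccc([N+](=O)[O-])cc2)C1)Nc1ccc([N+](=O)[O-])cc1` gives 1000 nM, the lowest number of the three, although its steps to both others stay within the usual scatter: a 1.7-fold lower number from compound 1 to compound 3 (0.23 log units; within the scatter) and a 1.4-fold lower number from compound 2 to compound 3 (0.15 log units; within the scatter).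

Compound 4 `O=C(/C=C/C(=O)N1C/C(=C\c2ccc([N+](=O)[O-])cc2)C(=O)/C(=C/c2ccc([N+](=O)[O-])cc2)C1)Nc1ccc(Cl)cc1` differs from compound 3 by chloro in place of nitro on an aromatic carbon. The measured steps that bear on this change are the two just named, together with a 1.2-fold lower number from compound 1 to compound 2 (0.08 log units; within the scatter). Each of them alters the substituent on the same anilide ring, and none of them moves the number beyond the scatter. The step from compound 3 to compound 4 is therefore expected to be small as well, with no clear direction, and is estimated as a 1.4-fold higher number from compound 3 to compound 4 (0.15 log units; within the scatter). Compound 4 is expected to give about 1400 nM in this assay, within a range from 700 nM to 2800 nM.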

Compound 4, half-maximal inhibitory concentration: 3600 nM
Compound 4: the middle estimate sits 2.6-fold (0.41 log units) below what was measured; measured number outside the range, above it.
By their numbers in this assay, from the lowest: compounds 3, 2 and 1 (each within the scatter of the next); then compound 4.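

In this assay, nitro, acetyl and the 3,4-dichlorophenyl pattern had all stayed within the scatter of one another, so the anilide ring looked tolerant of change, but a single chloro para to a large group breaks that picture, with a 3.6-fold higher number from compound 3 to compound 4 (0.56 log units; beyond the scatter) and a 2.6-fold higher number from compound 2 to compound 4 (0.41 log units; beyond the scatter) as the result. Removing one chloro from the dichloro ring also counts, giving a 2.1-fold higher number from compound 1 to compound 4 (0.33 log units; beyond the scatter) even though the chloro para to the large group stays in place, so the effect of a group here depends on what else the ring carries. Nothing available explains why these numbers differ.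

Going by these compounds, it remains open where a plain phenyl ring, or a methoxy or an amine at this place, would fall relative to compound 3 and compound 4. On these data alone, whether a second chloro on the ring would have the same effect alongside nitro or acetyl also remains open.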